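Aminomethyl in place of methoxy on the fused core

This account rests on a few compounds, and the source may have more. Where it says the series, first, only, none or still open, it means among the compounds named here.

Measured compounds in a functional assay on MCF7 cells (Homo sapiens) for cytotoxicity, read by neutral red uptake, with a stated time of 3 days; on this read-out higher numbers stand for weaker inhibition and lower numbers for stronger inhibition:
- compound 1 `Nc1ccc(-c2cc(=O)c3c(N)c(F)c(O)c(F)c3o2)cc1F`: compound 1 gives > 10000 nM, a limit of the assay.
- compound 2 `COc1c(F)c(N)c2c(=O)cc(-c3ccc(N)c(F)c3)oc2c1F`: compound 2 gives 100 nM.
- compound 3 `Nc1ccc(-c2cc(=O)c3c(N)c(F)c(Cl)c(F)c3o2)cc1F`: compound 3 gives 210 nM.

Compound 2 holds the lowest of the two numbers; the nearest is a 2.1-fold higher number from compound 2 to compound 3 (0.32 log units; beyond the scatter). Compound 1 contributes only a limit (the limit of > 10000 nM in this assay, at which 1 of the 3 values shown sits).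

Compound 4 `NCc1c(F)c(N)c2c(=O)cc(-c3ccc(N)c(F)c3)oc2c1F` differs from compound 2 by aminomethyl in place of methoxy on an aromatic carbon. Going by the values given here, two measured steps bear on this position: an at least 100-fold lower number from compound 1 to compound 2 (2.00 log units; beyond the scatter) and a 2.1-fold higher number from compound 2 to compound 3 (0.32 log units; beyond the scatter). Both replacements of the methoxy seen so far have raised the number, one by a large amount and one modestly, so a higher number is expected for compound 4, with wide uncertainty. Compound 4 is estimated at 700 nM, within 120 nM to 5000 nM. This estimate means a step of a 7.0-fold higher number from compound 2 to compound 4 (0.85 log units; beyond the scatter).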

Compound 4, half-maximal inhibitory concentration: 26 nM
Compound 4: middle estimate off by 27-fold (1.43 log units), on the high side; measured number outside the range, below it.
By their numbers in this assay, from the lowest: compound 4; then compound 2; then compound 3. At a limit, above all of these: compound 1.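

In this assay, the methoxy is not the group with the lowest number at this position: aminomethyl gives a 3.8-fold lower number from compound 2 to compound 4 (0.59 log units; beyond the scatter). Against chloro, the same group gives an 8.1-fold lower number from compound 3 to compound 4 (0.91 log units; beyond the scatter). Against hydroxy, it gives an at least 380-fold lower number from compound 1 to compound 4 (2.58 log units; beyond the scatter), a step that rests on the value of compound 1, which is a limit: the limit of > 10000 nM in this assay, at which 1 of the 4 values shown sits.

On these data alone, whether the lower number goes with the nitrogen itself or with the carbon that carries it stays open. An aminoethyl chain, a dimethylaminomethyl group or a carboxylic acid on this carbon would help separate the two.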